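A few compounds are considered here, and "the series" means these few. Any claim that something is new, unique, unknown or untested is made for them only; others in the source may bear on it.

The measured compounds, all in a functional assay on HepG2 cells (Homo sapiens) for antiproliferative activity, read by MTT assay, with a stated time of 48 h; a lower number here means a stronger inhibitor, a higher number a weaker inhibitor:

Compound 1 `O=C(/C=C/c1cccnc1)Nc1ccc2ncnc(Nc3cccc(Cl)c3)c2c1` gives 9120 nM.
Compound 2 `O=C(/C=C/c1ncc2ccccc2n1)Nc1ccc2ncnc(Nc3cccc(Cl)c3)c2c1` gives 7790 nM.
Compound 3 `O=C(/C=C/c1cccs1)Nc1ccc2ncnc(Nc3cccc(Cl)c3)c2c1` gives 10400 nM.

The three share one core and differ only in the aromatic group at the end of the double-bonded chain. Compound 3 carries the largest of the three numbers, yet none of the three stands apart from the others: the steps of a 1.1-fold higher number from compound 1 to compound 3 (0.06 log units; within the scatter) and a 1.3-fold higher number from compound 2 to compound 3 (0.13 log units; within the scatter) both fall inside the usual scatter, as does a 1.2-fold lower number from compound 1 to compound 2 (0.07 log units; within the scatter).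

Compound 4 `O=C(/C=C/c1cccnc1Cl)Nc1ccc2ncnc(Nc3cccc(Cl)c3)c2c1` continues this series with one further exchange at the same place: 2-chloropyridin-3-yl in place of thiophen-2-yl on a double-bonded chain carbon bound to a double-bonded chain carbon. Every step seen so far is of the same kind, an aromatic group swapped for another on that chain carbon, and every one of them left this assay essentially unmoved. Compound 1, whose pyridin-3-yl group is the closest relative of the entering 2-chloropyridin-3-yl, gives 9120 nM, which sits within scatter of compound 3. The expectation is therefore a step of a 1.2-fold lower number from compound 3 to compound 4 (0.06 log units; within the scatter) that does not exceed the scatter, in no particular direction. Compound 4 is estimated at 9000 nM, with a likely range from 4000 nM to 20000 nM.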

Compound 4, half-maximal inhibitory concentration: 4420 nM
Compound 4: middle estimate off by 2.0-fold (0.31 log units), on the high side; low and high end bracket the measured number.
By their numbers in this assay, from the lowest: compounds 4, 2, 1 and 3 (each within the scatter of the next, the first and the last beyond it).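

In this assay, the cleanest comparison is a single atom exchange, chloro in place of hydrogen on an aromatic carbon (a 2.1-fold lower number from compound 1 to compound 4 (0.31 log units; beyond the scatter)), and it shows that the group at the end of the chain can move this number beyond the scatter, if only modestly, which no swap among compound 1, compound 2 and compound 3 did. The exchange of thiophen-2-yl for 2-chloropyridin-3-yl (a 2.4-fold lower number from compound 3 to compound 4 (0.37 log units; beyond the scatter)) also passes the scatter, but the exchange of quinazolin-2-yl for the same group (a 1.8-fold lower number from compound 2 to compound 4 (0.25 log units; within the scatter)) stays within it, so compound 4 separates from only two of the three earlier compounds. Nothing available here bears on why the added chloro has this effect.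

From the compounds shown here alone, it remains open whether chlorine itself matters or whether a fluoro, methyl or methoxy group on the same aromatic carbon would give a similar step. Going by these compounds, it is also open whether a chloro on the thiophen-2-yl or quinazolin-2-yl group would shift those compounds in the same way.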